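The source may hold more compounds than are shown below. What is called first, only, known or untested is meant among the compounds shown, and "the series" means these compounds.

In a functional assay on MCF7 cells (Homo sapiens) for antiproliferative activity (on this read-out lower numbers stand for stronger inhibition and higher numbers for weaker inhibition), three compounds with a shared core differ at a single aromatic carbon. Compound 1 `C=CCc1cc(C(=O)Nc2cc3ccc(OC4CCN(C)CC4)c(C)c3oc2=O)ccc1OC(C)=O`, which carries allyl there, gives 2000 nM. Compound 2 `CC(=O)Oc1ccc(C(=O)Nc2cc3ccc(OC4CCN(C)CC4)c(C)c3oc2=O)cc1`, with hydrogen in that place, gives 1620 nM, and compound 3 `CC(=O)Oc1ccc(C(=O)Nc2cc3ccc(OC4CCN(C)CC4)c(C)c3oc2=O)cc1Cl`, with chloro, gives 1610 nM. Compound 3 therefore stands within the scatter of both other compounds, and the three are not separated on these numbers.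

Compound 4 `COc1cccc(-c2cc(C(=O)Nc3cc4ccc(OC5CCN(C)CC5)c(C)c4oc3=O)ccc2OC(C)=O)c1` follows from compound 3 by one change, 3-methoxyphenyl in place of chloro on an aromatic carbon, ortho to an acetoxy group. Among the measured compounds shown here, three measured steps bear on this place: a 1.2-fold lower number from compound 1 to compound 2 (0.09 log units; within the scatter), a 1.2-fold lower number from compound 1 to compound 3 (0.09 log units; within the scatter) and a 1.0-fold lower number from compound 2 to compound 3 (0.00 log units; within the scatter). All three lie within the scatter, so exchanging hydrogen, chloro and allyl has shown no measurable effect here. None of these three compounds has a ring at this place, however, so the data do not directly cover the incoming group, and the uncertainty is wide. No step beyond the scatter is therefore expected, and the estimate means a 1.2-fold lower number from compound 3 to compound 4 (0.06 log units; within the scatter). For compound 4, the estimated value is 1400 nM, with an expected range from 500 nM to 3200 nM.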

Compound 4, half-maximal inhibitory concentration: 910 nM
Compound 4: the middle estimate sits 1.5-fold (0.19 log units) above what was measured; low and high end bracket the measured number.
By their numbers in this assay, from the lowest: compounds 4, 3, 2 and 1 (each within the scatter of the next, the first and the last beyond it).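

Compound 4 puts the first ring at this place, an aromatic ring of eight heavy atoms with its methoxy group, and in this assay the larger group is tolerated: a 1.8-fold lower number from compound 3 to compound 4 (0.25 log units; within the scatter) and a 1.8-fold lower number from compound 2 to compound 4 (0.25 log units; within the scatter) both remain within the scatter, so replacing chloro or hydrogen with 3-methoxyphenyl has no measurable effect. Only the exchange for allyl clears the scatter, with a 2.2-fold lower number from compound 1 to compound 4 (0.34 log units; beyond the scatter), a modest step and the first at this place to do so. No measurement at hand accounts for this step.

The compounds shown leave open whether that modest step belongs to the aromatic ring itself or to its methoxy group, a question that a plain phenyl group, or a phenyl group carrying an amine or a carboxylic acid instead of methoxy, would bear on. They also leave open whether a longer chain at this place would stand with allyl or with 3-methoxyphenyl, and whether any group here can move the number further than this single step beyond the scatter.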